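The compounds below may be only part of what the source reports. "The series", "measured", "known", "first", "only" and "open" are said of these compounds alone.

Compound 1 `CNC(=O)Nc1ccc(-c2nc(N3CC4CCC(C3)O4)c3cnn([C@H]4CC[C@@H](OC)CC4)c3n2)cc1` gives 1 nM in a functional assay on LNCaP cells (Homo sapiens) for cytotoxicity (on this read-out higher numbers stand for weaker inhibition and lower numbers for stronger inhibition), the lowest of the three numbers in hand. Compound 2 `O=C(Nc1ccccc1)Nc1ccc(-c2nc(N3CC4CCC(C3)O4)c3cnn(C4CCC5(CC4)OCCO5)c3n2)cc1` gives 4 nM and compound 3 `CNC(=O)Nc1ccc(-c2nc(N3CC4CCC(C3)O4)c3cnn(C(C)C)c3n2)cc1` gives 5 nM. Going by the values given here, the only measured step at the same place, a 5.0-fold higher number from compound 1 to compound 3 (0.70 log units; beyond the scatter), is modest though beyond the scatter. Compound 4 `CNC(=O)Nc1ccc(-c2nc(N3CC4CCC(C3)O4)c3cnn([C@H]4CC[C@@H](O)CC4)c3n2)cc1` differs from compound 1 by hydrogen in place of methyl on an oxygen on a saturated carbon. Among the compounds with values here, no measured step bears directly on this change: the step from compound 1 to compound 3 exchanges the whole 4-methoxycyclohexyl, whereas here only the methyl on the oxygen leaves, and compound 2, carrying a different group on the aromatic nitrogen, also gives a low number. The step is therefore expected to be small, a 2.0-fold higher number from compound 1 to compound 4 (0.30 log units; within the scatter). Compound 4 is estimated at 2 nM, between 0.7 nM and 6 nM.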

Compound 4, half-maximal inhibitory concentration: 20 nM
Beside the measured number, compound 4's estimate is 10-fold (1.00 log units) below it; the whole stated range lies below it.
By their numbers in this assay, from the lowest: compound 1; then compounds 2 and 3 (each within the scatter of the next); then compound 4.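

Within the 4-substituted cyclohexyl on the aromatic nitrogen, the methyl on the oxygen carries much of the result: methoxy to hydroxy alone gives a 20-fold higher number from compound 1 to compound 4 (1.30 log units; beyond the scatter) in this assay. The cyclohexyl is therefore not enough by itself, since the hydroxy compound also falls behind the simple isopropyl, with a 4.0-fold higher number from compound 3 to compound 4 (0.60 log units; beyond the scatter) on the same read-out. Nothing in hand explains this step.

Open, on these data alone, is whether a longer chain on the oxygen, such as ethoxy, keeps the low number of compound 1. Also open, as far as these compounds go, is how an amine at the same carbon would compare.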